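The compounds below may be only part of what the source reports. "The series", "measured", "known", "first", "only" and "open" are said of these compounds alone.

Compound 2 `CCOC(=O)C1=C(Nc2ccccc2)S/C(=C\c2cccnc2)C1=O` sits at a limit of the assay: in a functional assay on A549 cells (Homo sapiens) for inhibition, read by MTT assay, with a stated time of 72 h, tested at 10 uM (on this read-out higher numbers stand for more inhibition at the one concentration tested (going by the name of the read-out) and lower numbers for less inhibition), compound 2 gives < 10%, the limit described as the limit of < 10% in this assay, at which 1 of the 2 values shown sits. Compound 1 `CCOC(=O)C1=C(Nc2ccccc2)S/C(=C\c2ccc(OC)cc2)C1=O` is the only other point; in this assay compound 1 gives 17.5%. Among the compounds with values here, the single measured step, a number at least 7.5 percentage points lower from compound 1 to compound 2 (that floor lies within the scatter), does not touch the change now in question. Compound 3 `CCOC(=O)C1=C(Nc2ccccc2)S/C(=C\c2cc3cccnc3[nH]2)C1=O` carries a group of 9 heavy atoms (7 carbon, 2 nitrogen; one five-membered aromatic ring with 1 hetero atom, one six-membered aromatic ring with 1 hetero atom) in place of a group of 6 heavy atoms (5 carbon, 1 nitrogen; one six-membered aromatic ring with 1 hetero atom), on a double-bonded chain carbon bound to a double-bonded ring carbon. Within the data shown here, with no step to lean on, no shift beyond the scatter is expected in this assay. The estimate for compound 3 is 10%, with a range from 0% to 25%. The expected step is a number no lower from compound 2 to compound 3 (the limit leaves the size open).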

Compound 3, a percentage reported as inhibition, at one concentration (the size of the read-out at that concentration, not a potency): 16.7%
For compound 3 the middle estimate is 6.7 percentage points below the measured one; low and high end bracket the measured number.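

In this assay, the group of 9 heavy atoms with a five-membered and a six-membered aromatic ring, in place of pyridin-3-yl on the double-bonded chain carbon, gives a number at least 6.7 percentage points higher from compound 2 to compound 3 (that floor lies within the scatter). That step has only a floor, and compound 2 remains a limit, not a number: the limit of < 10% in this assay, at which 1 of the 3 values shown sits. In place of 4-methoxyphenyl, the same group gives a number 0.8 percentage points lower from compound 1 to compound 3 (within the scatter), so this position accepts the larger aromatic group with no shift beyond the scatter.

From the compounds shown here alone, whether an amine or a carboxylic acid at this place would move the inhibition beyond the scatter stays open. The compounds shown also do not separate the added ring from the added hydrogen-bond donor.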